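The compounds below may be only part of what the source reports. "The series", "measured", "known", "first", "only" and "open" are said of these compounds alone.

Compound 3 `O=C(CCl)Nc1ccc(C(=O)/C=C/c2ccccc2Cl)cc1` gives 5260 nM in a functional assay on MCF7 cells (Homo sapiens) for cytotoxicity, read by MTT assay, with a stated time of 72 h (a higher number here means a weaker inhibitor, a lower number a stronger inhibitor), which places it at the top of the three numbers shown, although its steps to both other compounds lie within the scatter: compound 2 `O=C(CCl)Nc1ccc(C(=O)/C=C/c2ccc(Br)cc2)cc1` gives 4640 nM and compound 1 `O=C(CCl)Nc1ccc(C(=O)/C=C/c2ccc(Cl)cc2)cc1` gives 4100 nM. The measured steps, a 1.1-fold higher number from compound 1 to compound 2 (0.05 log units; within the scatter), a 1.3-fold higher number from compound 1 to compound 3 (0.11 log units; within the scatter) and a 1.1-fold higher number from compound 2 to compound 3 (0.05 log units; within the scatter), each concern only the chlorophenyl or bromophenyl group and none reaches beyond the scatter. Compound 4 `O=C(CSC(=S)N[C@H]1CCOC1=O)Nc1ccc(C(=O)/C=C/c2ccccc2Cl)cc1` differs elsewhere: a group of 10 heavy atoms (5 carbon, 1 nitrogen, 2 oxygen, 2 sulfur; one five-membered non-aromatic ring with 1 hetero atom) in place of one chlorine atom, on a saturated chain carbon bound to a carbonyl carbon. Among the compounds with values here, no measured step touches this place, so the series offers no direct guide; compound 3 alone serves as anchor. The expected step is a 1.1-fold lower number from compound 3 to compound 4 (0.02 log units; within the scatter), with no change beyond the scatter but wide uncertainty. Compound 4 is estimated at 5000 nM, within 1500 nM to 16000 nM.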

Compound 4, half-maximal inhibitory concentration: 5570 nM
Estimate against measurement, compound 4: 1.1-fold (0.05 log units) below; measured number inside the range.
By their numbers in this assay, from the lowest: compounds 1, 2, 3 and 4 (each within the scatter of the next).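

In this assay, the group of 10 heavy atoms in place of the chlorine, on a saturated chain carbon bound to a carbonyl carbon, gives a 1.1-fold higher number from compound 3 to compound 4 (0.02 log units; within the scatter). This first measured step at this place shows that the chlorine can be exchanged for a far larger group bearing a five-membered non-aromatic ring without a change beyond the scatter. No available evidence bears on this result.

Still open, going by these compounds, is whether an amine or a carboxylic acid at this place would give a step beyond the scatter. On these data alone, the opposite stereocentre in the entering group is also open.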